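This account rests on a few compounds, and the source may have more. Where it says the series, first, only, none or still open, it means among the compounds named here.

Of the compounds shown here, three with a shared core have been measured in a functional assay on A549 cells (Homo sapiens) for antiproliferative activity, read by MTT assay, with a stated time of 48 h; a higher number here means a weaker inhibitor, a lower number a stronger inhibitor. Compound 1 `COc1cc(-c2cccc3nc(-c4ccccc4)oc23)cc(OC)c1OC`, with hydrogen at the place of interest, gives 20300 nM. Compound 2 `COc1cccc(-c2nc3cccc(-c4cc(OC)c(OC)c(OC)c4)c3o2)c1` carries a methoxy group there and gives 3500 nM. Compound 3 `COc1cc(-c2cccc3nc(-c4cccc(C)c4)oc23)cc(OC)c1OC` carries a methyl group there and gives 16700 nM. Compound 3 thus stands level with compound 1 and clearly on the weaker side of compound 2, as a 4.8-fold higher number from compound 2 to compound 3 (0.68 log units; beyond the scatter) shows.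

The next structure is compound 4 `COc1cc(-c2cccc3nc(-c4cccc(N)c4)oc23)cc(OC)c1OC`, where amino takes the place of methyl on an aromatic carbon, meta to a large group: amino in place of methyl on an aromatic carbon. Among the compounds with values here, two measured steps bear on this. Adding the methyl group of compound 3 changed little, a 1.2-fold lower number from compound 1 to compound 3 (0.08 log units; within the scatter), while adding the methoxy group of compound 2 gave a modest drop, a 5.8-fold lower number from compound 1 to compound 2 (0.76 log units; beyond the scatter). Within the data shown here, no amino compound has been measured yet, so the guide is imperfect. Amino resembles methoxy in joining the ring through an atom other than carbon, so compound 4 is expected to lean toward compound 2, though with wide uncertainty. The expected move is a 2.8-fold lower number from compound 3 to compound 4 (0.44 log units; beyond the scatter), a modest step toward a lower number. For compound 4 the estimated value is 6000 nM. The expected range for compound 4 runs from 1800 nM to 20000 nM.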

Compound 4, half-maximal inhibitory concentration: 4700 nM
Estimate against measurement, compound 4: 1.3-fold (0.11 log units) above; measured number inside the range.
By their numbers in this assay, from the lowest: compounds 2 and 4 (each within the scatter of the next); then compounds 3 and 1 (each within the scatter of the next).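

In this assay this place on the ring turns out to respond to more than methoxy alone: amino in place of hydrogen gives a 4.3-fold lower number from compound 1 to compound 4 (0.64 log units; beyond the scatter) and amino in place of methyl gives a 3.6-fold lower number from compound 3 to compound 4 (0.55 log units; beyond the scatter). Amino and methoxy cannot be told apart here, since amino in place of methoxy gives only a 1.3-fold higher number from compound 2 to compound 4 (0.13 log units; within the scatter), so two different groups, one joined to the ring through nitrogen and the other through oxygen, now sit level, while methyl, joined through carbon, stays level with hydrogen. That split rests on just these four compounds, and no measurement at hand says what lies behind it.

Still open, as far as these compounds go, is whether the split holds for other groups joined through a non-carbon atom, such as hydroxy, a dimethylamino group or an acetamide, and whether a carbon-joined group such as a carboxylic acid or a longer chain would stay level with hydrogen as methyl does. Also open, from the compounds shown here alone, is whether the same order of groups would appear on cells other than this one line.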